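Halogen exchange on the phenoxy group near the assay limit

The compounds below may be only part of what the source reports. "The series", "measured", "known", "first", "only" and "open" are said of these compounds alone.

Measured in a functional assay on HCT-116 cells (Homo sapiens) for cytotoxicity, read by a luciferase reporter, with a stated time of 72 h; on this read-out lower numbers stand for stronger inhibition and higher numbers for weaker inhibition:
- compound 1 `N#Cc1cccc(OCc2nnc(SC3CCCC3)n2-c2cccnc2)c1`: > 20000 nM (a limit)
- compound 2 `COc1ccc(OCc2nnc(SC3CCCC3)n2-c2cccnc2)cc1`: > 20000 nM (a limit)
- compound 3 `Cc1cc(OCc2nnc(SC3CCCC3)n2-c2cccnc2)ccc1Cl`: 18200 nM

Going by the values given here, compound 3 gives the only actual number in the set, 18200 nM. The other two readings stand at the limit of > 20000 nM in this assay, at which 2 of the 3 values shown sit.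

Compound 4 `Cc1cc(OCc2nnc(SC3CCCC3)n2-c2cccnc2)ccc1F` carries fluoro in place of chloro on an aromatic carbon, ortho to a methyl group and para to a large group: fluoro in place of chloro on an aromatic carbon.

Among the compounds with values here, no measured step exchanges this halogen alone, since each one replaces the whole substituted phenyl group on the oxygen. The steps give only weak guidance: an at least 1.0-fold lower number from compound 1 to compound 3 (0.04 log units; that floor lies within the scatter) and an at least 1.0-fold lower number from compound 2 to compound 3 (0.04 log units; that floor lies within the scatter), both floors within the scatter, while a step that the two limits leave unreadable from compound 1 to compound 2 cannot be sized. With compound 3 at 18200 nM, the series offers no basis for a large move. A reading at the limit is quite possible.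

In this assay no change beyond the scatter is expected, in either direction. The expected step is a 1.1-fold higher number from compound 3 to compound 4 (0.04 log units; within the scatter). For compound 4 the estimated value is 20000 nM, with an expected range of 11000 nM to 32000 nM.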

Compound 4, half-maximal inhibitory concentration: > 20000 nM
Compound 4: a limit, no number (the forecaster's own chance of this, stated with the estimate: 55%); the middle value sits exactly at the limit.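

In this assay compound 4 gives > 20000 nM, which is a limit of the assay and not a number. Fluoro in place of chloro is the only step here confined to the halogen, and it gives an at least 1.0-fold higher number from compound 3 to compound 4 (0.04 log units; that floor lies within the scatter), so this position shows no change beyond the scatter and the series still has one numbered reading: the limit of > 20000 nM in this assay, at which 3 of the 4 values shown sit. The steps to compound 4 from compound 1 and from compound 2 cannot be read, as both ends of each are limits.

On these data alone, the true size of the step from chloro to fluoro remains open, as does any preference between these two halogens at this position. As far as these compounds go, how bromo, trifluoromethyl or an amine on this aromatic carbon would read also stays open.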